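Series notes: from compound 3 to compound 4

The source may hold more compounds than are shown below. What is called first, only, known or untested is meant among the compounds shown, and "the series" means these compounds.

Measured in a functional assay on HeLa cells (Homo sapiens) for antiproliferative activity, read by MTT assay, with a stated time of 72 h (on this read-out lower numbers stand for stronger inhibition and higher numbers for weaker inhibition), each value a limit of the assay and not a number:
- compound 1 `COc1cc(-c2nccn2C(C)C)cc(OC)c1OC`: > 100000 nM
- compound 2 `CCCCCn1ccnc1-c1cc(OC)c(OC)c(OC)c1`: > 100000 nM
- compound 3 `COc1cc(-c2nccn2Cc2ccccc2)cc(OC)c1OC`: > 100000 nM

Compound 3 gives no number to work from, only the limit > 100000 nM. The whole measured set stands at one place: the limit of > 100000 nM in this assay, at which 3 of the 3 values shown sit.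

Next is compound 4 `COc1cc(-c2nccn2-c2ccc(F)cc2)cc(OC)c1OC`, with this change: 4-fluorophenyl in place of benzyl on an aromatic nitrogen. In words, it has 4-fluorophenyl in place of benzyl on an aromatic nitrogen.

Going by the values given here, three measured steps bear on this nitrogen: a step that the two limits leave unreadable from compound 1 to compound 2, a step that the two limits leave unreadable from compound 1 to compound 3 and a step that the two limits leave unreadable from compound 2 to compound 3. None has a readable size, so together they fix no size for the coming step. In compound 1, compound 2 and compound 3 a saturated carbon is bound to that nitrogen, whereas compound 4 has an aromatic ring there, so the measured steps do not cover this change.

Another limit in this assay is about as likely as a number, and any readable step is expected to point toward stronger inhibition. The expected change is an at least 3.3-fold lower number from compound 3 to compound 4 (0.52 log units; beyond the scatter). For compound 4 the estimate is 30000 nM, with an expected range from 1000 nM to 100000 nM.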

Compound 4, half-maximal inhibitory concentration: 17500 nM
Compound 4: middle estimate off by 1.7-fold (0.23 log units), on the high side; measured number inside the range.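

In this assay, 4-fluorophenyl on the aromatic nitrogen in place of benzyl gives an at least 5.7-fold lower number from compound 3 to compound 4 (0.75 log units; beyond the scatter). The same group gives an at least 5.7-fold lower number from compound 2 to compound 4 (0.75 log units; beyond the scatter) in place of pentyl and an at least 5.7-fold lower number from compound 1 to compound 4 (0.75 log units; beyond the scatter) in place of isopropyl, so among the compounds shown, only the one with an aromatic ring bound directly to this nitrogen gives a number rather than a limit. The steps among compound 1, compound 2 and compound 3 cannot be read, and these three compounds stay together: the limit of > 100000 nM in this assay, at which 3 of the 4 values shown sit.

Compound 4 differs from compound 3 both in the direct attachment of the ring and in the fluorine, and the compounds shown do not separate these two features. From the compounds shown here alone, a plain phenyl on this nitrogen would separate them, while the outcome with 4-methoxyphenyl or 4-aminophenyl there remains open.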